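Side-chain carbamate change from compound 2 onward

This account rests on a few compounds, and the source may have more. Where it says the series, first, only, none or still open, it means among the compounds named here.

Measured compounds:
compound 1 `COc1cc2ncnc(-n3nc(-c4ccccn4)nc3N)c2cc1[N+](=O)[O-]` — in an assay on MCF7 cells for inhibition of Serine-protein kinase ATM (Homo sapiens), read by immunofluorescence, with a stated time of 1 h (a lower number here means a stronger inhibitor, a higher number a weaker inhibitor), compound 1 gives 31100 nM
compound 2 `COc1cc2ncnc(-n3nc(-c4ccccn4)nc3N)c2cc1OCCNC(=O)OC(C)(C)C` — in this assay compound 2 gives 800 nM

Among the compounds with values here, compound 2 holds the lowest number of the two; the one step between them, a 39-fold lower number from compound 1 to compound 2 (1.59 log units; beyond the scatter), is the only measured step in the set. Compound 3 `CCOC(=O)NCCCOc1cc2c(-n3nc(-c4ccccn4)nc3N)ncnc2cc1OC` has not been measured. It differs from compound 2 in one place: ((ethoxycarbonyl)amino)methyl in place of (tert-butoxycarbonyl)amino on a saturated chain carbon, two bonds along the chain from an oxygen on an aromatic ring. Within the data shown here, no measured step involves such a change; the step from compound 1 to compound 2 exchanges a nitro group for the whole carbamate-bearing side chain and so does not bear on a swap of one carbamate ester for another with the chain lengthened. With nothing to point either way, the number for compound 3 is expected to stay close to that of compound 2. The step of no change at the digits printed from compound 2 to compound 3 (within the scatter) is therefore estimated as none beyond the scatter. Compound 3 is estimated at 800 nM in this assay, with a range from 250 nM to 2500 nM.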

Compound 3, half-maximal inhibitory concentration in the Serine-protein kinase ATM assay: 800 nM
For compound 3 middle estimate and measured number coincide at the digits printed, and the stated range covers the measured number.
By their numbers in the Serine-protein kinase ATM assay, from the lowest: compounds 2 and 3 (each within the scatter of the next); then compound 1.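

In the Serine-protein kinase ATM assay, this place on the chain accepts ((ethoxycarbonyl)amino)methyl in place of (tert-butoxycarbonyl)amino, with no change at the digits printed from compound 2 to compound 3 (within the scatter). The advantage over the nitro group therefore does not depend on the tert-butyl carbamate, with a 39-fold lower number from compound 1 to compound 3 (1.59 log units; beyond the scatter). The same change does separate the two compounds in a physicochemical assay for solubility, in phosphate buffer, with a stated time of 18 h, at pH 7.4; a lower number here means a less soluble compound, a higher number a more soluble compound: the measured solubility of compound 2, 2000 nM, and of compound 3, 16000 nM, an 8.0-fold higher number (0.90 log units; beyond the scatter). In the physicochemical assay, compound 2 gives 2000 nM and compound 3 gives 16000 nM.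

The exchange of 2-((tert-butoxycarbonyl)amino)ethoxy for 3-((ethoxycarbonyl)amino)propoxy alters the carbamate ester and the chain length together, so the share of each in the difference in the physicochemical assay remains unresolved. Also open, from the compounds shown here alone, is how a free amine or a carboxylic acid at the chain end, or a longer chain, would read in the Serine-protein kinase ATM assay.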